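Ether side-chain replacements on the shared core

The source may report more compounds than this note shows. Statements on the series, on what has been measured and on what is new or still open speak of the compounds shown alone.

Compound 1 `COc1cc(OC)c(-c2coc3cc(OCC=C(C)C)ccc3c2=O)cc1OC` is the reference point of this set. In a functional assay on HCT-116 cells (Homo sapiens) for antiproliferative activity, read by MTT assay, with a stated time of 24 h (a higher number here means a weaker inhibitor, a lower number a stronger inhibitor), compound 1 gives 680 nM, the lowest of the two numbers in hand. Its nearest neighbour is compound 2 `C#CCOc1ccc2c(=O)c(-c3cc(OC)c(OC)cc3OC)coc2c1`; in this assay compound 2 gives 8050 nM, a step of a 12-fold higher number from compound 1 to compound 2 (1.07 log units; beyond the scatter). Compound 3 `COc1cc(OC)c(-c2coc3cc(OCc4ccc([N+](=O)[O-])cc4)ccc3c2=O)cc1OC` returns only a limit in this assay, > 10000 nM. From compound 1 the change reads an at least 14-fold higher number from compound 1 to compound 3 (1.16 log units; beyond the scatter), and from compound 2 it reads an at least 1.2-fold higher number from compound 2 to compound 3 (0.09 log units; that floor lies within the scatter). One of the three values sits at the limit of > 10000 nM in this assay, at which 1 of the 3 values shown sits.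

Compound 4 `COc1cc(OC)c(-c2coc3cc(OCc4ccc(C(F)(F)F)cc4)ccc3c2=O)cc1OC` differs from compound 1 by 4-(trifluoromethyl)phenyl in place of 2-methylprop-1-en-1-yl on a saturated chain carbon bound to an oxygen on an aromatic ring. Both measured steps away from compound 1 bear on this change: a 12-fold higher number from compound 1 to compound 2 (1.07 log units; beyond the scatter) and an at least 14-fold higher number from compound 1 to compound 3 (1.16 log units; beyond the scatter), each large and upward, and the second carries the closer analogue, another benzyl ether bearing a substituted phenyl group. A large upward step is therefore expected for compound 4, a 13-fold higher number from compound 1 to compound 4 (1.12 log units; beyond the scatter). Compound 4 is estimated at 9000 nM, within a range of 3000 nM to 30000 nM, with a real chance that this assay reports only a limit.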

Compound 4, half-maximal inhibitory concentration: 2440 nM
For compound 4 the middle estimate is 3.7-fold (0.57 log units) above the measured one, and the stated range ends above it.
By their numbers in this assay, from the lowest: compound 1; then compound 4; then compound 2. At a limit, above all of these: compound 3.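

In this assay, going by these compounds alone, a phenyl ring on this saturated chain carbon need not cost as much as compound 3 suggested: a 3.6-fold higher number from compound 1 to compound 4 (0.55 log units; beyond the scatter), a modest step where the earlier steps away from compound 1 were large, though compound 1 still has the lowest number. The substituent on the phenyl ring therefore matters, with trifluoromethyl in place of nitro on an aromatic carbon giving an at least 4.0-fold lower number from compound 3 to compound 4 (0.61 log units; beyond the scatter), and the 4-(trifluoromethyl)phenyl group also outperforms ethynyl, giving a 3.3-fold lower number from compound 2 to compound 4 (0.52 log units; beyond the scatter). The figure for compound 3 is a limit, not a number, so its step gives only a floor: the limit of > 10000 nM in this assay, at which 1 of the 4 values shown sits.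

Two substituted benzyl ethers support no trend across phenyl substituents. On these data alone, it remains open whether an amine or a carboxylic acid on that ring, or a longer chain in place of 3-methylbut-2-en-1-yl, would reach or pass compound 1.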